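Swapping a Methoxymethyl for a Pyrrolidine Amide

A few compounds are considered here, and "the series" means these few. Any claim that something is new, unique, unknown or untested is made for them only; others in the source may bear on it.

Compound 1 `CCCCCOC(=O)N1CCN(C(=O)[C@H](CCC(=O)O)NC(=O)c2cc(N3CCC(COC)CC3)nc(-c3ccccc3)n2)CC1`: > 80%, a limit of the assay.
Compound 2 `CCCCCOC(=O)N1CCN(C(=O)[C@H](CCC(=O)O)NC(=O)c2nc(-c3ccccc3)cc(N3CCC(COC)CC3)n2)CC1`: > 80%, also a limit of the assay.

Both compounds were tested in an ADME assay on microsomes from liver (Rattus norvegicus) for metabolic stability; a higher number here means that more of the compound is left, a lower number that less of the compound is left. In this assay compound 1 reaches > 80%, which is a limit of the assay rather than an exact number. The same holds for compound 2, which reaches > 80%. Compound 1 therefore stands at the top of what the measurements can show: the limit of > 80% in this assay, at which 2 of the 2 values shown sit. For the measured compounds named here, no pair of measured compounds differs in only one place, so no measured step is available to guide the next move.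

Compound 3 `CCCCCOC(=O)N1CCN(C(=O)[C@H](CCC(=O)O)NC(=O)c2cc(N3CCC(C(=O)N4CCCC4)CC3)nc(-c3ccccc3)n2)CC1` has not yet been tested in this assay. It differs from compound 1 as follows: (pyrrolidin-1-yl)carbonyl in place of methoxymethyl on a saturated ring carbon. Going by the values given here, nothing among the measured compounds tells how such a change would act in this assay. The expected step is a step that the limit leaves unreadable from compound 1 to compound 3, which means no move beyond the scatter. Compound 3 is expected to give 82%, with a range from 60% to 95%.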

Compound 3, percent of the compound remaining: > 80%
Compound 3 ended at the assay's limit; the forecaster's own chance of this, stated with the estimate: 60%; the middle value lies beyond the limit too.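

Compound 3 gives > 80% in this assay, which is a limit of the assay. The swap from compound 1 to compound 3 therefore yields no readable step, because both compounds sit at the same limit: the limit of > 80% in this assay, at which 3 of the 3 values shown sit.

The compounds shown leave open whether (pyrrolidin-1-yl)carbonyl in place of methoxymethyl changes the amount of compound left at all, and which change to these compounds would bring a result under the limit.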